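Fluoro for Trifluoromethyl: Estimating Compound 4

This account rests on a few compounds, and the source may have more. Where it says the series, first, only, none or still open, it means among the compounds named here.

Of the compounds shown here, three have been measured in a functional assay on BGC-823 cells (Homo sapiens) for antiproliferative activity, read by MTT assay, tested at 5 uM; on this read-out lower numbers stand for a weaker effect and higher numbers for a stronger effect at the one concentration tested. Compound 2 `COc1cc(C(=O)N/N=C/c2ccccc2C(F)(F)F)cc(OC)c1OC` gives 35.6%, the highest of the three numbers. Compound 1 `COc1cc(C2=NN(C(C)=O)C(c3c(Cl)cccc3Cl)O2)cc(OC)c1OC` gives 15.9% and compound 3 `COc1cc(C2=NN(C(C)=O)C(c3ccc(F)cc3)O2)cc(OC)c1OC` gives 13.3%; both lie beyond the scatter below compound 2. Going by the values given here, the only measured one-place step, a number 2.6 percentage points lower from compound 1 to compound 3 (within the scatter), stayed within the scatter, but it swaps a whole aryl group on a different core and so does not speak directly to the change here. Compound 4 `COc1cc(C(=O)N/N=C/c2ccccc2F)cc(OC)c1OC` differs from compound 2 by fluoro in place of trifluoromethyl on an aromatic carbon. Among the compounds with values here, with no measured step testing this swap, the step is expected to be small and uncertain in direction, estimated as a number 5.6 percentage points lower from compound 2 to compound 4 (within the scatter). Compound 4 is therefore estimated at 30%, within a range from 12% to 50%.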

Compound 4, a percentage reported as inhibition, at one concentration (the size of the read-out at that concentration, not a potency): 76.5%
Estimate against measurement, compound 4: 46.5 percentage points below; measured number above the stated range.
By their numbers in this assay, from the lowest: compounds 3 and 1 (each within the scatter of the next); then compound 2; then compound 4.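

In this assay, the swap of trifluoromethyl for fluoro on this aromatic carbon, ortho to a large group, gives a number 40.9 percentage points higher from compound 2 to compound 4 (beyond the scatter). The earlier compounds shown here did not test this position, and this step shows that a change here alone can move the read-out by far more than the scatter. Nothing measured here bears on why the number rises.

Going by these compounds, only these two groups are compared at this position, so it remains open how an amine or a nitrile would read there. On these data alone, whether the same swap has a similar effect on the core of compound 1 also remains open.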